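This account rests on a few compounds, and the source may have more. Where it says the series, first, only, none or still open, it means among the compounds named here.

Of the compounds shown here, three built on one shared core have been measured in an assay for binding affinity to metabotropic glutamate receptor 5 (Rattus norvegicus); on this read-out higher numbers stand for weaker inhibition and lower numbers for stronger inhibition. Compound 1 `Cc1cnccc1-c1cc(F)cc(-n2nnc(-c3ccccn3)n2)c1` gives 33 nM, compound 2 `Cc1ncccc1-c1cc(F)cc(-n2nnc(-c3ccccn3)n2)c1` gives 45 nM, and compound 3 `Nc1ccncc1-c1cc(F)cc(-n2nnc(-c3ccccn3)n2)c1` gives 20 nM. Compound 3 holds the lowest of the three numbers: the step of a 1.7-fold lower number from compound 1 to compound 3 (0.22 log units; within the scatter) stays within the scatter, while the step of a 2.3-fold lower number from compound 2 to compound 3 (0.35 log units; beyond the scatter) reaches beyond it. The step of a 1.4-fold higher number from compound 1 to compound 2 (0.13 log units; within the scatter) shows that rearranging the methylpyridyl group moves this assay only a little.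

Compound 4 `Nc1cccnc1-c1cc(F)cc(-n2nnc(-c3ccccn3)n2)c1` is the next variant: 3-aminopyridin-2-yl in place of 4-aminopyridin-3-yl on an aromatic carbon. This change rearranges the aminopyridyl group in the same spirit as the earlier rearrangements, each of which shifted this assay by a small amount. The change from compound 3 to compound 4 is therefore expected to be small, probably not beyond the scatter, with a slight lean toward a higher number because compound 3 sits at 20 nM, the lowest point so far. The expected step is a 1.8-fold higher number from compound 3 to compound 4 (0.24 log units; within the scatter). Compound 4 is estimated at 35 nM, within a range from 12 nM to 100 nM.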

Compound 4, inhibition constant: 31 nM
The estimate for compound 4 lay 1.1-fold (0.05 log units) above the measured number, within the range that was stated.
By their numbers in this assay, from the lowest: compounds 3, 4, 1 and 2 (each within the scatter of the next, the first and the last beyond it).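

Swapping 4-aminopyridin-3-yl for 3-aminopyridin-2-yl keeps the same atoms but joins them differently, and in this assay this gives a 1.6-fold higher number from compound 3 to compound 4 (0.19 log units; within the scatter), so moving the amino group and ring nitrogen around the pyridine is tolerated here, as rearranging the methylpyridyl group was. The other two steps, a 1.5-fold lower number from compound 2 to compound 4 (0.16 log units; within the scatter) and a 1.1-fold lower number from compound 1 to compound 4 (0.03 log units; within the scatter), show that compound 4 cannot be told apart from either methylpyridyl compound, even though compound 3 and compound 2 do differ beyond the scatter. Nothing available explains these small differences.

Still open, from the compounds shown here alone, is whether a methoxy group or a chlorine atom in place of the amino group would shift this assay beyond the scatter. A plain phenyl ring at this position, without any ring nitrogen, is equally unexplored in these compounds.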